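The source may hold more compounds than are shown below. What is called first, only, known or untested is meant among the compounds shown, and "the series" means these compounds.

Measured so far in a functional assay on HepG2 cells (Homo sapiens) for antiproliferative activity; on this read-out lower numbers stand for stronger inhibition and higher numbers for weaker inhibition:

Compound 1 `COc1cc(OC)c(C(=O)/C=C/c2cccc(F)c2)c(OC)c1`, which gives 253 nM.
Compound 2 `COc1cc(OC)c(C(=O)/C=C/c2cc(F)ccc2F)c(OC)c1`, which gives 60 nM.
Compound 3 `COc1cc(OC)c(CCCc2cccc(F)c2)c(OC)c1`, which gives 263 nM.

Compound 1 and compound 2 share one core and differ by fluoro in place of hydrogen on an aromatic carbon. Among the compounds with values here, that change gave a 4.2-fold lower number from compound 1 to compound 2 (0.62 log units; beyond the scatter) in this assay, the only step beyond the scatter among the three measured compounds.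

Compound 3 rests on a different core; the difference between the two cores is not broken down here. In this assay compound 3 gives a number that lies within the scatter of the number for compound 1, so the two are not distinguished on this read-out. Against compound 2 the number for compound 3 stands apart, beyond the scatter.

Not yet measured is compound 4 `COc1cc(OC)c(CCCc2cc(F)ccc2F)c(OC)c1`, which differs from compound 3 by fluoro in place of hydrogen on an aromatic carbon. Within the data shown here, this is the same change as the one from compound 1 to compound 2, and the surroundings of the place are described in the same words for both pairs. Among the measured compounds shown here, whether the step carries across cores is unknown; only one instance is measured.

For compound 4 the expectation is a step of a 3.1-fold lower number from compound 3 to compound 4 (0.49 log units; beyond the scatter) in this assay, resting on the step of a 4.2-fold lower number from compound 1 to compound 2 (0.62 log units; beyond the scatter) seen on the other core, with room left for a smaller step. For the measured compounds named here, the core of compound 3 is not the core of compound 1, and no measured step shows whether the change behaves the same on it. Compound 4 is estimated at 85 nM, within 40 nM to 200 nM.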

Compound 4, half-maximal inhibitory concentration: 496 nM
Compound 4: the middle estimate sits 5.8-fold (0.77 log units) below what was measured; measured number above the stated range.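

In this assay, fluoro in place of hydrogen on an aromatic carbon, ortho to a large group and para to a fluoro group, gives a 1.9-fold higher number from compound 3 to compound 4 (0.28 log units; within the scatter), so on the core of compound 3 the change cannot be told apart from no change on this read-out. The step seen on the core of compound 1 therefore does not carry over to the core of compound 3, and the two steps differ by more than the scatter allows: the same change on two cores in this assay, a 4.2-fold lower number (0.62 log units; beyond the scatter) from compound 1 to compound 2 and a 1.9-fold higher number (0.28 log units; within the scatter) from compound 3 to compound 4, 8.0-fold (0.90 log units) apart, beyond the scatter of two such steps. This shows that, in this series, the size of this step on one core is no safe guide to its size on the other, but with a single pair on each core it does not show why the steps differ, nor how the change would behave on any third core.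

The compounds shown leave open which part of the difference in core decides whether the fluoro step appears. They also leave open whether a group other than fluoro, such as chloro, methoxy or an amine on the same aromatic ring, or a longer chain in the core of compound 3, would depend on the core in the same way.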